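From propoxycarbonyl to ethylcarbamoyl on the shared core

The source may report more compounds than this note shows. Statements on the series, on what has been measured and on what is new or still open speak of the compounds shown alone.

Measured in a functional assay on cells (Platelet, Homo sapiens) for inhibition; on this read-out higher numbers stand for weaker inhibition and lower numbers for stronger inhibition:
- compound 1 `CCOC(=O)c1ccc(-c2nn(Cc3ccccc3OC)c3ccccc23)cc1` gives > 10000 nM, a limit
- compound 2 `CCCOC(=O)c1ccc(-c2nn(Cc3ccccc3)c3ccccc23)cc1` gives > 10000 nM, a limit

Neither entry is a number, so compound 2 has no defined position in the series. Both compounds sit at the same ceiling: the limit of > 10000 nM in this assay, at which 2 of the 2 values shown sit. Among the compounds with values here, the two compounds therefore cannot be ranked, and no measured step is available to calibrate the next change.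

Compound 3 `CCNC(=O)c1ccc(-c2nn(Cc3ccccc3)c3ccccc23)cc1` keeps the shared core and carries ethylamino in place of propoxy on a carbonyl carbon, which turns propoxycarbonyl into ethylcarbamoyl: ethylamino in place of propoxy on a carbonyl carbon.

Within the data shown here, with no measured step to draw on, the expectation in this assay is of a modest shift towards stronger inhibition at best, and possibly none beyond the scatter. This rests on compound 2 at > 10000 nM, which fixes only a starting limit and not a starting value. The estimated size of the change is a number no higher from compound 2 to compound 3 (the limit leaves the size open). A reading at the limit again remains the more likely outcome. For compound 3 the expected value is 10000 nM, with an estimated range of 2500 nM to 30000 nM.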

Compound 3, half-maximal inhibitory concentration: > 10000 nM
Compound 3 gave a limit, no number; the forecaster's own chance of this, stated with the estimate: 60%; the middle value lies on the limit itself.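

In this assay compound 3 gives > 10000 nM, a limit and not a number. No step can be read from compound 2 to compound 3, since both sit at the same ceiling: the limit of > 10000 nM in this assay, at which 3 of the 3 values shown sit. The compounds shown leave open how ethylcarbamoyl and propoxycarbonyl actually compare, and whether any compound on the shared core gives a numerical value in this assay.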